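Naphthyl replacing bromophenyl in an inactive pyridazinone pair

The source may report more compounds than this note shows. Statements on the series, on what has been measured and on what is new or still open speak of the compounds shown alone.

Compound 1 `Cc1cc(Cc2cccc(Cl)c2)c(=O)n(CC(=O)Nc2ccc(Br)cc2)n1` and compound 2 `Cc1cc(Cc2cccc(Br)c2)c(=O)n(CC(=O)Nc2ccc(Br)cc2)n1` differ only at the pendant aryl group. In a functional assay on HL-60 cells (Homo sapiens), read by calcium flux (on this read-out lower numbers stand for an effect already at smaller amounts and higher numbers for an effect only at larger amounts of compound), compound 1 gives > 50000 nM, which is a limit of the assay. In this assay compound 2 likewise gives > 50000 nM, again a limit and not a number. Within the data shown here, the one measured step, a step that the two limits leave unreadable from compound 1 to compound 2, cannot be read because of the limit of > 50000 nM in this assay, at which 2 of the 2 values shown sit. Compound 2 therefore stands at the assay limit, with no measured potency to anchor it.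

Compound 3 `Cc1cc(Cc2cccc3ccccc23)c(=O)n(CC(=O)Nc2ccc(Br)cc2)n1` is the next member. Its change from compound 2 is naphthalen-1-yl in place of 3-bromophenyl on a saturated chain carbon bound to an aromatic carbon. Among the measured compounds shown here, no measured step bears on a change of this kind; the only step available is the unreadable one from compound 1 to compound 2. With compound 2 at the limit, the expected step of a number no higher from compound 2 to compound 3 (the limit leaves the size open) is essentially unconstrained, and a further limit is the likeliest outcome. The estimate for compound 3 in this assay is 50000 nM, within 8000 nM to 300000 nM.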

Compound 3, half-maximal effective concentration: > 50000 nM
Compound 3: a limit, no number; the forecaster's own chance of this, stated with the estimate: 75%; the middle value sits exactly at the limit.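

In this assay compound 3 gives > 50000 nM, a limit and not a number. No step linking compound 3 to compound 1 or compound 2 can be read: the limit of > 50000 nM in this assay, at which 3 of the 3 values shown sit.

The compounds shown leave open whether any pendant aryl group on the shared core gives a measurable potency.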